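A few compounds are considered here, and "the series" means these few. Any claim that something is new, unique, unknown or untested is made for them only; others in the source may bear on it.

Compound 2 `C#CCOc1cccc(/C=C/C(=O)Nc2cc(C(=O)c3cc(OC)c(OC)c(OC)c3)ccc2OC)c1` gives 14000 nM in a functional assay on HeLa cells (Homo sapiens) for cytotoxicity, read by MTT assay, with a stated time of 72 h (a lower number here means a stronger inhibitor, a higher number a weaker inhibitor), and compound 1 `COc1ccc(/C=C/C(=O)Nc2cc(C(=O)c3cc(OC)c(OC)c(OC)c3)ccc2OC)cc1` gives 10700 nM; the step of a 1.3-fold higher number from compound 1 to compound 2 (0.12 log units; within the scatter) lies within the scatter, so the two stand together. Compound 3 `COc1ccc(C(=O)c2cc(OC)c(OC)c(OC)c2)cc1NC(=O)/C=C/c1ccc(F)cc1` is the next variation on the same position: 4-fluorophenyl in place of 3-(propargyloxy)phenyl on a double-bonded chain carbon bound to a double-bonded chain carbon. Within the data shown here, the only measured step at this position, a 1.3-fold higher number from compound 1 to compound 2 (0.12 log units; within the scatter), stayed within the scatter, which is the sole guide for this change, so no move beyond the scatter in either direction is expected in this assay. Compound 3 is therefore estimated at 12000 nM, with a range from 5000 nM to 28000 nM. The expected step is a 1.2-fold lower number from compound 2 to compound 3 (0.07 log units; within the scatter).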

Compound 3, half-maximal inhibitory concentration: 60 nM
Beside the measured number, compound 3's estimate is 200-fold (2.30 log units) above it; measured number below the stated range.
By their numbers in this assay, from the lowest: compound 3; then compounds 1 and 2 (each within the scatter of the next).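

In this assay this position is far from flat: 4-fluorophenyl in place of 3-(propargyloxy)phenyl gives a 230-fold lower number from compound 2 to compound 3 (2.37 log units; beyond the scatter) and fluoro in place of methoxy on an aromatic carbon gives a 180-fold lower number from compound 1 to compound 3 (2.25 log units; beyond the scatter) while the earlier pair stayed within the scatter. The similar numbers of compound 1 and compound 2 therefore did not mark a general insensitivity at this position. Nothing available explains the size of these steps.

Going by these compounds, whether this gain is specific to fluoro remains open. Chloro, hydroxy or amino on the same ring, or a bare phenyl, would show how narrow the requirement is.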